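The source may hold more compounds than are shown below. What is called first, only, known or untested is meant among the compounds shown, and "the series" means these compounds.

Compound 3 `COc1cc(-c2nn(-c3cccc(NC(=O)c4ccc(Cl)c(C(F)(F)F)c4)c3)cc2-c2ccncc2)ccc1Cl` stands in a functional assay on SW-620 cells (Homo sapiens) for inhibition, read by sulforhodamine B assay, with a stated time of 48 h (on this read-out higher numbers stand for weaker inhibition of growth and lower numbers for stronger inhibition of growth), only at a limit, > 32500 nM, not at a number (the limit of > 32500 nM in this assay, at which 1 of the 3 values shown sits). Compound 4 `COc1cc(-c2nn(-c3cccc(NC(=O)Nc4ccc(Cl)c(C(F)(F)F)c4)c3)cc2-c2ccncc2)ccc1Cl` keeps the shared core and alters the group on the carbonyl carbon: (4-chloro-3-(trifluoromethyl)phenyl)amino in place of 4-chloro-3-(trifluoromethyl)phenyl on a carbonyl carbon. One measured step runs in the opposite direction: compound 2 `COc1cc(-c2nn(-c3cccc(NC(=O)Nc4cccc(C(F)(F)F)c4)c3)cc2-c2ccncc2)ccc1Cl` gives 14300 nM, and the step of an at least 2.2-fold higher number from compound 2 to compound 3 (0.35 log units; beyond the scatter) exchanged an amino-bearing group for a plain aryl group. Compound 1 `COc1cc(-c2nn(-c3cccc(NC(=O)Nc4ccc(Cl)c(Cl)c4)c3)cc2-c2ccncc2)ccc1Cl` gives only a limit, > 50000 nM (the limit of > 50000 nM in this assay, at which 1 of the 3 values shown sits). The step that the two limits leave unreadable from compound 1 to compound 3 is therefore unreadable, while the step of an at least 3.4-fold lower number from compound 1 to compound 2 (0.54 log units; beyond the scatter) shows that the aryl part of the urea matters. Restoring the urea is expected to lower the number, so compound 4 is estimated at 20000 nM (range 6000 nM to 50000 nM), a step of an at least 1.6-fold lower number from compound 3 to compound 4 (0.21 log units; that floor lies within the scatter).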

Compound 4, concentration for total growth inhibition: 29900 nM
Compound 4: middle estimate off by 1.5-fold (0.17 log units), on the low side, and the stated range covers the measured number.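

Adding chloro to the aromatic ring of the urea weakens growth inhibition, with a 2.1-fold higher number from compound 2 to compound 4 (0.32 log units; beyond the scatter), so this one atom separates two otherwise identical ureas. Trifluoromethyl in place of chloro gives an at least 1.6-fold lower number from compound 1 to compound 4 (0.22 log units; that floor lies within the scatter), and the urea nitrogen gives an at least 1.0-fold lower number from compound 3 to compound 4 (0.03 log units; that floor lies within the scatter); both of these floors lie within the scatter. Going by these compounds, compound 1 and compound 3 stand only at limits, so the true size of these two steps remains unknown.

On these data alone, it remains open whether this loss is specific to chloro. A nitrile or a methyl in its place could show whether other groups there behave the same way.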